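A ring swap on compound 3

The compounds below may be only part of what the source reports. "The series", "measured", "known", "first", "only" and "open" are said of these compounds alone.

In a physicochemical assay for solubility, read by spectrophotometry, measured as kinetic solubility, at pH 8, tested at 500 uM (on this read-out lower numbers stand for lower solubility and higher numbers for higher solubility), compound 1 `CNS(=O)(=O)c1ccccc1Nc1cc(-c2ccc3ccn(C)c3c2)c2nccnc2c1` gives 2 ug/mL, compound 2 `Cn1ccc2ccc(-c3cc(Nc4ccccc4S(=O)(=O)N4CCOCC4)cc4nccnc34)cc21` gives 5 ug/mL, and compound 3 `Cn1cc(CNC(=O)c2ccncc2Nc2cc(-c3ccc4ccn(C)c4c3)c3nccnc3c2)cn1` gives 127 ug/mL, the highest of these three numbers and well clear of the other two. Compound 4 `CC(=O)N1CCOC(CNC(=O)c2ccncc2Nc2cc(-c3ccc4ccn(C)c4c3)c3nccnc3c2)C1` differs from compound 3 in one group: 4-acetylmorpholin-2-yl in place of 1-methyl-1H-pyrazol-4-yl on a saturated chain carbon bound to an amide-type nitrogen.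

For the measured compounds named here, only one measured step brings in a morpholine-type group: a 2.5-fold higher number from compound 1 to compound 2 (0.40 log units; beyond the scatter), with morpholin-4-yl in place of methylamino on a sulfonyl sulfur. That step is modest and happens on a sulfonyl sulfur, not on a chain carbon. Going by the values given here, no measured step removes 1-methyl-1H-pyrazol-4-yl, so the hint upward is weak. In this assay, no change beyond the scatter is therefore expected, and the estimated step is a 1.2-fold higher number from compound 3 to compound 4 (0.07 log units; within the scatter). For compound 4 the estimated value is 150 ug/mL, with an expected range of 60 ug/mL to 280 ug/mL.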

Compound 4, solubility: 268 ug/mL
For compound 4 the middle estimate is 1.8-fold (0.25 log units) below the measured one, within the range that was stated.
By their numbers in this assay, from the lowest: compound 1; then compound 2; then compound 3; then compound 4.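

At this place, on a saturated chain carbon bound to an amide-type nitrogen, a five-membered aromatic ring can give way to a six-membered non-aromatic ring without losing the high number of compound 3, and in this assay the swap gives a 2.1-fold higher number from compound 3 to compound 4 (0.32 log units; beyond the scatter). For the compounds shown here, this is the first step at this place, and it is modest, but it lies beyond the usual scatter even though both groups have the same counts of hydrogen-bond donors and acceptors and neither carries a net charge. Nothing measured here explains why the number rises.

Going by these compounds, how much of the step belongs to the ring and how much to the acetyl group stays open, and a morpholine with a free amine in place of the acetylated nitrogen would separate the two. Also open, on these data alone, is how a carboxylic acid at this same place would read in this assay.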